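Compound 2 and an untested change on the carbonyl carbon

The compounds below may be only part of what the source reports. "The series", "measured", "known", "first", "only" and "open" are said of these compounds alone.

In an ADME assay on microsomes from liver (Homo sapiens) for metabolic stability, read by LC-MS, using NADPH, with a stated time of 30 min, tested at 0.1 uM (on this read-out higher numbers stand for a more stable compound and lower numbers for a less stable compound), compound 1 `Cc1cc(C#N)cnc1C(=O)Nc1ccc(F)c([C@]2(C)C=C(CF)OC(N)=N2)c1` gives 63% and compound 2 `C[C@@]1(c2cc(NC(=O)c3ncc(OCF)nc3N)ccc2F)C=C(CF)OC(N)=N1` gives 67% of the compound remaining, so the two stand level within the scatter. Compound 3 `C[C@@]1(c2cc(NC(=O)c3coc(CF)n3)ccc2F)C=C(CF)OC(N)=N1` has 2-(fluoromethyl)-1,3-oxazol-4-yl in place of 3-amino-5-(fluoromethoxy)pyrazin-2-yl on a carbonyl carbon. Among the measured compounds shown here, the only measured step at this place, a number 4 percentage points higher from compound 1 to compound 2 (within the scatter), stayed small, although no measured compound carries the entering group. No shift beyond the scatter is therefore expected, and the estimated change is a number 4 percentage points lower from compound 2 to compound 3 (within the scatter) in this read-out. Compound 3 is expected at 63% within an estimated range from 45% to 79% for now.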

Compound 3, percent of the compound remaining: 76%
Compound 3: middle estimate off by 13 percentage points, on the low side; the measured number falls inside the stated range.
By their numbers in this assay, from the lowest: compounds 1, 2 and 3 (each within the scatter of the next, the first and the last beyond it).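

In this assay, the 2-(fluoromethyl)-1,3-oxazol-4-yl group is the first five-membered aromatic ring shown on this carbonyl carbon, and it keeps the read-out level with the 3-amino-5-(fluoromethoxy)pyrazin-2-yl group, with a number 9 percentage points higher from compound 2 to compound 3 (within the scatter) as the step. Against the 5-cyano-3-methylpyridin-2-yl group, the same ring gives the first step at this place to pass the scatter, a number 13 percentage points higher from compound 1 to compound 3 (beyond the scatter) and so this position is not indifferent to the group it carries. Nothing available explains this difference. On these data alone, what part the fluoromethyl group plays remains open, as does how a plain methyl on the same 1,3-oxazol-4-yl ring would read.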